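The compounds below may be only part of what the source reports. "The series", "measured", "known", "first", "only" and "open" are said of these compounds alone.

Three compounds built on one shared core were tested in a functional assay on MCF7 cells (Homo sapiens) for cytotoxicity, read by MTT assay, with a stated time of 24 h, tested at 32 ug/mL; on this read-out lower numbers stand for a weaker effect and higher numbers for a stronger effect at the one concentration tested. Compound 1 `Cn1c(-c2ccc(NC(=O)CCl)cc2)nc(-c2ccccc2)c1-c1ccccc1` gives 42.8%, compound 2 `Cn1cnnc1SCC(=O)Nc1ccc(-c2nc(-c3ccccc3)c(-c3ccccc3)n2C)cc1` gives 89.2%, and compound 3 `CCN1CCN(CC(=O)Nc2ccc(-c3nc(-c4ccccc4)c(-c4ccccc4)n3C)cc2)CC1` gives 38.6%, the smallest of the three numbers, though its gap to compound 1 lies within the scatter, while a number 50.6 percentage points lower from compound 2 to compound 3 (beyond the scatter). The step of a number 4.2 percentage points lower from compound 1 to compound 3 (within the scatter) shows that swapping the group on the chain carbon bound to the carbonyl carbon need not move the read-out at all. Compound 4 `Cn1c(-c2ccc(NC(=O)CN3CCN(Cc4ccc(Cl)cc4)CC3)cc2)nc(-c2ccccc2)c1-c1ccccc1` differs from compound 3 at another place: 4-chlorophenyl in place of methyl on a saturated chain carbon bound to an amine nitrogen in a ring. For the measured compounds named here, no measured step touches that place, so the expected step of a number 1.4 percentage points higher from compound 3 to compound 4 (within the scatter) is none beyond the scatter. Compound 4 is therefore estimated at 40%, with a range from 25% to 60%.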

Compound 4, a percentage reported as activity, at one concentration (the size of the read-out at that concentration, not a potency): 52.8%
Estimate against measurement, compound 4: 12.8 percentage points below; the measured number falls inside the stated range.
By their numbers in this assay, from the lowest: compounds 3, 1 and 4 (each within the scatter of the next, the first and the last beyond it); then compound 2.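

With 4-chlorophenyl in place of methyl on a saturated chain carbon bound to an amine nitrogen in a ring, this assay shows a number 14.2 percentage points higher from compound 3 to compound 4 (beyond the scatter), so a second place on these compounds, beyond the chain carbon bound to the carbonyl carbon, can also move the read-out. The change from ethyl to 4-chlorobenzyl brings in one six-membered aromatic ring and a chlorine. No measurement here explains the step. The compounds shown leave open whether the step goes with the ring or with its chlorine: a plain benzyl group at this place would separate the two.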